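From a Chlorofluorophenyl Group to a Furan

A few compounds are considered here, and "the series" means these few. Any claim that something is new, unique, unknown or untested is made for them only; others in the source may bear on it.

For the measured compounds named here, only two compounds have been measured so far in a functional assay on MKN-45 cells (Homo sapiens) for cytotoxicity, read by MTT assay, with a stated time of 72 h (on this read-out lower numbers stand for stronger inhibition and higher numbers for weaker inhibition), for this comparison. Compound 2 (`O=C(N/N=C/c1ccc(F)cc1Cl)N1CCc2ncnc(Nc3cccc(Br)c3)c2C1`) gives 1710 nM and holds the lower of the two numbers. Compound 1 (`O=C(N/N=C/c1cccs1)N1CCc2ncnc(Nc3ccc(F)c(Cl)c3)c2C1`) gives 57300 nM and lies well beyond the usual scatter from it. Compound 3 (`O=C(N/N=C/c1ccco1)N1CCc2ncnc(Nc3cccc(Br)c3)c2C1`) has not yet been measured. It carries furan-2-yl in place of 2-chloro-4-fluorophenyl on a carbon with a double bond to nitrogen. Going by the values given here, no clean single-change step is available as a guide. The nearest hint is compound 1 at 57300 nM with a five-membered aromatic ring on that carbon, though it differs elsewhere too. A moderate loss of strength is therefore expected, with an estimated 3.5-fold higher number from compound 2 to compound 3 (0.55 log units; beyond the scatter) toward weaker inhibition. Compound 3 is expected at 6000 nM with a likely range of 1500 nM to 24000 nM on this estimate.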

Compound 3, half-maximal inhibitory concentration: 65700 nM
Compound 3: middle estimate off by 11-fold (1.04 log units), on the low side; measured number outside the range, above it.
By their numbers in this assay, from the lowest: compound 2; then compounds 1 and 3 (each within the scatter of the next).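

In this assay, for the compounds shown here, replacing the 2-chloro-4-fluorophenyl group, which sits on a carbon with a double bond to nitrogen, by furan-2-yl gives a 38-fold higher number from compound 2 to compound 3 (1.58 log units; beyond the scatter), the first step here in which only one part of the molecule differs. It shows that this position is sensitive: with everything else unchanged, the exchange of this one group moves the number well beyond the scatter, toward weaker inhibition. No measurement at hand explains the loss.

The step changes several things at once, including the ring size, the two halogens and the ring oxygen, so it cannot show which of them matters. Going by these compounds, whether a plain phenyl ring on that carbon would behave more like 2-chloro-4-fluorophenyl or more like furan-2-yl remains open, as does whether a pyridine ring would keep the strength of compound 2.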